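A few compounds are considered here, and "the series" means these few. Any claim that something is new, unique, unknown or untested is made for them only; others in the source may bear on it.

Measured in an ADME assay on MDCK cells (Canis lupus familiaris) for cytotoxicity, with a stated time of 24 h; a lower number here means that less compound is tolerated, a higher number that more compound is tolerated:
- compound 1 `CCC(CC)O[C@@H]1C=C(C(=O)Nc2ccccc2)C[C@H](N)[C@H]1NC(C)=O`: 151000 nM
- compound 2 `CCC(CC)O[C@@H]1C=C(C(=O)Nc2ccccc2OC)C[C@H](NC(=O)OC(C)(C)C)[C@H]1NC(C)=O`: > 1000000 nM, a limit of the assay and not a number

Compound 2 has no number of its own and stands at the limit of > 1000000 nM in this assay, at which 1 of the 2 values shown sits. Compound 3 `CCC(CC)O[C@@H]1C=C(C(=O)Nc2ccccc2OC)C[C@H](N)[C@H]1NC(C)=O` is compound 2 with hydrogen in place of tert-butoxycarbonyl on an amine nitrogen, leaving amino where (tert-butoxycarbonyl)amino stood: hydrogen in place of tert-butoxycarbonyl on an amine nitrogen. Within the data shown here, no measured step covers this change. Among the measured compounds shown here, the expectation rests on compound 1, the one measured compound with amino at that nitrogen, which gives 151000 nM. A move towards less compound tolerated in this assay, well beyond the scatter, is expected, and the expected size is an at least 6.6-fold lower number from compound 2 to compound 3 (0.82 log units; beyond the scatter). The estimated value for compound 3 is 150000 nM. The expected range for compound 3 runs from 50000 nM to 450000 nM.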

Compound 3, half-maximal cytotoxic concentration: 75300 nM
Beside the measured number, compound 3's estimate is 2.0-fold (0.30 log units) above it; low and high end bracket the measured number.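

In this assay, the step of an at least 13-fold lower number from compound 2 to compound 3 (1.12 log units; beyond the scatter) puts a measured size on leaving amino where (tert-butoxycarbonyl)amino stood, and that size is a lower bound only. Compound 2 stands at a limit of the assay and not at a number: the limit of > 1000000 nM in this assay, at which 1 of the 3 values shown sits.

With amino held at that nitrogen, methoxy in place of hydrogen on an aromatic carbon gives a 2.0-fold lower number from compound 1 to compound 3 (0.30 log units; within the scatter) in this assay, so this aromatic change does not separate the two compounds here.

The compounds shown leave open how an acetyl group or a methyl carbamate on the same nitrogen would read, and so whether tolerance tracks tert-butoxycarbonyl alone or any acylated amine. They also leave open whether a longer alkoxy chain, such as ethoxy, or a chlorine on that aromatic carbon would move the number beyond the scatter.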